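The source may report more compounds than this note shows. Statements on the series, on what has been measured and on what is new or still open speak of the compounds shown alone.

Working notes on the series, read in a functional assay on cells (Erythrocyte, Rattus norvegicus) for inhibition, read by hemolysis, with a stated time of 1 h; on this read-out lower numbers stand for stronger inhibition and higher numbers for weaker inhibition. Of the compounds shown here, two have numbers so far. Compound 1 (`COc1cc(OC)c(-c2cc(=O)c3ccc(O)cc3o2)cc1OC`) gives 2.15 ug/mL. Compound 2 (`COc1cc(OC)c(OC)cc1/C=C/C(=O)c1cc(Cl)ccc1O`) gives 2.23 ug/mL, which places compound 2 within the scatter of compound 1, so the pair sets no order.

Compound 3 (`COc1cc(OC)c(OC)cc1/C=C/C(=O)c1ccc(Br)cc1`) is the next to be read, and it differs from compound 2 on a carbonyl carbon: 4-bromophenyl in place of 5-chloro-2-hydroxyphenyl on a carbonyl carbon. The 4-bromophenyl group thus takes the place of the 5-chloro-2-hydroxyphenyl group. For the measured compounds named here, no measured pair isolates this change, so there is no step to carry over, and the forecast starts from compound 2 at 2.23 ug/mL. With so little to go on, only a small move is expected, toward a higher number and so weaker inhibition in this assay, and it may not clear the scatter. The expected change is a 1.4-fold higher number from compound 2 to compound 3 (0.16 log units; within the scatter). For compound 3 the estimated value is 3.2 ug/mL, with an expected range of 1.2 ug/mL to 9 ug/mL.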

Compound 3, half-maximal inhibitory concentration: 2.3 ug/mL
Beside the measured number, compound 3's estimate is 1.4-fold (0.14 log units) above it; measured number inside the range.
By their numbers in this assay, from the lowest: compounds 1, 2 and 3 (each within the scatter of the next).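

For the compounds shown here, the change on the carbonyl carbon, 4-bromophenyl in place of 5-chloro-2-hydroxyphenyl, gives in this assay a 1.0-fold higher number from compound 2 to compound 3 (0.01 log units; within the scatter), the first step that isolates a single place. At this place the read-out therefore does not separate the two groups, although 5-chloro-2-hydroxyphenyl counts 1 hydrogen-bond donor and 1 hydrogen-bond acceptor and 4-bromophenyl counts 0 of each. Nothing in hand gives an independent measurement that would account for this result.

This single step swaps the chlorine, the hydroxyl and the bromine together, so the share of each in the outcome cannot be told apart, and two groups that read alike may hide opposing contributions or none at all. From the compounds shown here alone, whether the flat result holds for a different kind of group on the same carbonyl carbon, such as a phenyl ring carrying an amine or a carboxylic acid, remains open.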